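Swapping the sulfonyl aryl group on a quinolinone core

The source may hold more compounds than are shown below. What is called first, only, known or untested is meant among the compounds shown, and "the series" means these compounds.

Measured compounds:
- compound 1 `COC(=O)c1cc(=O)c2c(OC)cc(OC)cc2n1S(=O)(=O)c1ccc(C)cc1`: 5800 nM
- compound 2 `COc1ccc(-c2cc(=O)c3c(OC)cc(OC)cc3n2S(=O)(=O)c2ccc([N+](=O)[O-])cc2)cc1`: "not determined" (no result reported)

In a functional assay on SEM cells (Homo sapiens) for antiproliferative activity, with a stated time of 72 h (a higher number here means that more compound is needed for the effect, a lower number that less compound is needed), compound 1 gives 5800 nM. Compound 2 shares the two methoxy groups and the sulfonyl-bearing nitrogen of that core but carries a 4-methoxyphenyl where compound 1 carries a methyl ester, and a 4-nitrophenyl on the sulfonyl sulfur; for compound 2 the result in this assay is "not determined" (no result reported), so it cannot be placed against compound 1.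

Compound 3 `COc1ccc(-c2cc(=O)c3c(OC)cc(OC)cc3n2S(=O)(=O)c2c(F)c(F)c(F)c(F)c2F)cc1` is compound 2 with one change: 2,3,4,5,6-pentafluorophenyl in place of 4-nitrophenyl on a sulfonyl sulfur. Among the measured compounds shown here, no pair of measured compounds shows what such a swap does in this assay, and compound 2 itself has no value, so no direction of step can be read from the data. The expectation therefore rests only on compound 1, and the half-maximal effective concentration for compound 3 in this assay is estimated at 3000 nM, with a wide range from 400 nM to 20000 nM.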

Compound 3, half-maximal effective concentration: 3900 nM
Compound 3: the middle estimate sits 1.3-fold (0.11 log units) below what was measured, within the range that was stated.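

Compound 2 has no value to set against compound 3, so no step can be read between them. Nothing available here bears on a cause for the result of compound 3. From the compounds shown here alone, what replacing 4-nitrophenyl with 2,3,4,5,6-pentafluorophenyl does to antiproliferative activity remains open.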